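The compounds below may be only part of what the source reports. "The series", "measured", "known", "first", "only" and "open" are said of these compounds alone.

Measured compounds:
compound 1, `O=C1O/C(=C\Cn2c(=O)[nH]c(=O)[nH]c2=O)C(OCc2ccccc2)=C1OCc1ccccc1`, 37900 nM
compound 2, `Nc1ccn(CCC2(N)OC(=O)C(OCc3ccccc3)=C2OCc2ccccc2)c(=O)n1`, > 100000 nM

Among the measured compounds shown here, in a functional assay on MIA PaCa-2 cells (Homo sapiens) for inhibition, read by MTT assay, with a stated time of 72 h (on this read-out higher numbers stand for weaker inhibition and lower numbers for stronger inhibition), compound 1 gives 37900 nM, the only numerical value among the two measured compounds. Compound 2 reaches only a limit of this assay, > 100000 nM, and no number is known for it; the pattern is summarised by the limit of > 100000 nM in this assay, at which 1 of the 2 values shown sits. Compound 3, `Nc1ncn(C/C=C2\OC(=O)C(OCc3ccccc3)=C2OCc2ccccc2)c(=O)n1`, has not yet been measured. Compared with compound 1 it carries a group of 8 heavy atoms (3 carbon, 4 nitrogen, 1 oxygen; one six-membered aromatic ring with 3 hetero atoms) in place of a group of 9 heavy atoms (3 carbon, 3 nitrogen, 3 oxygen; one six-membered aromatic ring with 3 hetero atoms), on a saturated chain carbon bound to a double-bonded chain carbon. Since no step between two measured compounds is shown, the size of this change cannot be read from the data; with compound 1 already weak and compound 2 beyond the assay range, the step from compound 1 to compound 3 is expected to be small, at most toward weaker inhibition, and possibly none beyond the usual scatter. Compound 3 is therefore expected to give about 50000 nM, within a range from 15000 nM to 150000 nM, the expected step being a 1.3-fold higher number from compound 1 to compound 3 (0.12 log units; within the scatter).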

Compound 3, half-maximal inhibitory concentration: 920 nM
For compound 3 the middle estimate is 54-fold (1.74 log units) above the measured one; the measured number lies below the stated range.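

In this assay, among the compounds shown here, exchanging the group on a saturated chain carbon bound to a double-bonded chain carbon gives a 41-fold lower number from compound 1 to compound 3 (1.61 log units; beyond the scatter), the first step that can be read. It shows that this place is sensitive: with the shared core unchanged, a change confined to the group bearing the six-membered aromatic ring with 3 hetero atoms moves the read-out well beyond the scatter, and the entering group, with 4 nitrogen and 1 oxygen, goes with the stronger inhibition. Nothing measured here gives a cause for this step.

On these data alone, it remains open whether an amine or a carboxylic acid in this place would keep or lose the gain. As far as these compounds go, it also remains open how a longer chain leading to the entering ring would affect it.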